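Trading a Cyclopentyloxy Ring for a Butylsulfanyl Chain

This account rests on a few compounds, and the source may have more. Where it says the series, first, only, none or still open, it means among the compounds named here.

Compound 1 `CCCN(CCC)c1nc(C(C)(C)C)ccc1CNC(=O)C(C)c1ccc(NS(C)(=O)=O)c(F)c1` gives 2.5 nM in an assay on cells for antagonist activity at transient receptor potential cation channel subfamily V member 1 (Homo sapiens), read by FLIPR and calcium flux, with a stated time of 6 min; a lower number here means a stronger inhibitor, a higher number a weaker inhibitor. Compound 2 `CCOc1nc(C(C)(C)C)ccc1CNC(=O)C(C)c1ccc(NS(C)(=O)=O)c(F)c1` gives 14.8 nM in this assay. Compound 3 `CC(C(=O)NCc1ccc(C(C)(C)C)nc1OC1CCCC1)c1ccc(NS(C)(=O)=O)c(F)c1` gives 1.5 nM in this assay.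

All three share one core and differ only in the group attached to the aromatic carbon beside the tert-butyl-bearing ring. Compound 3 holds the lowest of the three numbers, yet compound 1 lies close to it: the step of a 1.7-fold lower number from compound 1 to compound 3 (0.22 log units; within the scatter) is within the scatter, so the two cannot be ranked. Compound 2 stands clearly apart, as the step of a 9.9-fold lower number from compound 2 to compound 3 (0.99 log units; beyond the scatter) shows.

Compound 4 `CCCCSc1nc(C(C)(C)C)ccc1CNC(=O)C(C)c1ccc(NS(C)(=O)=O)c(F)c1` is the next variation: butylsulfanyl in place of cyclopentyloxy on an aromatic carbon. Among the compounds with values here, two measured steps bear on this. The step of a 9.9-fold lower number from compound 2 to compound 3 (0.99 log units; beyond the scatter) shows that a short ethyl chain on the oxygen gave a markedly higher number than the cyclopentyl ring. The step of a 1.7-fold lower number from compound 1 to compound 3 (0.22 log units; within the scatter) shows that a larger, branched dipropylamino group stayed within the scatter of the ring. Butylsulfanyl is a chain, like ethoxy, but longer, and carries sulfur rather than oxygen; no measured pair tests sulfur here. A modest rise in number, smaller than the ethoxy case, is therefore expected, as a 3.3-fold higher number from compound 3 to compound 4 (0.52 log units; beyond the scatter).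

Compound 4 is estimated at 5 nM, with a range from 1.5 nM to 20 nM.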

Compound 4, inhibition constant: 3.2 nM
Beside the measured number, compound 4's estimate is 1.6-fold (0.19 log units) above it, and the stated range covers the measured number.
By their numbers in this assay, from the lowest: compounds 3, 1 and 4 (each within the scatter of the next, the first and the last beyond it); then compound 2.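

A ring at this position, next to the ring nitrogen, is not needed for a low number: in this assay the open butylsulfanyl chain loses only a modest amount against the cyclopentyloxy ring (a 2.1-fold higher number from compound 3 to compound 4 (0.33 log units; beyond the scatter)) and cannot be ranked against dipropylamino (a 1.3-fold higher number from compound 1 to compound 4 (0.11 log units; within the scatter)). The chain also gives a clearly lower number than ethoxy (a 4.6-fold lower number from compound 2 to compound 4 (0.67 log units; beyond the scatter)), but that step lengthens the chain and replaces oxygen with sulfur together, so it cannot show which of the two changes matters. Nothing shown here explains these differences.

A butoxy group, which puts the same chain on oxygen, and an ethylsulfanyl group, which puts the short chain on sulfur, would separate the atom from the chain length. Going by these compounds, it also remains open whether a cyclopentylsulfanyl group, with the ring kept on sulfur, or a longer chain such as hexylsulfanyl would keep the number as low at this position.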